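Cytotoxicity notes on the shared-core series, amine variation

The source may hold more compounds than are shown below. What is called first, only, known or untested is meant among the compounds shown, and "the series" means these compounds.

Measured compounds:
- compound 1 `COc1cc2cc(C#N)ccc2c(OC)c1Oc1cc(NCC(C)C)nc(Nc2ccc(C#N)cc2)n1`: in an ADME assay on MT4 cells (Homo sapiens) for cytotoxicity, read by MTT assay, with a stated time of 5 days (a lower number here means that less compound is tolerated, a higher number that more compound is tolerated), compound 1 gives > 125000 nM, which is a limit of the assay and not a number.
- compound 2 `COc1cc2cc(C#N)ccc2c(OC)c1Oc1cc(NC2CC2)nc(Nc2ccc(C#N)cc2)n1`: in this assay compound 2 gives > 125000 nM, likewise a limit of the assay.

Among the measured compounds shown here, the single step between measured compounds, a step that the two limits leave unreadable from compound 1 to compound 2, has no readable size; both of its ends are limits. Compound 2 therefore stands at the limit in this assay, and the other value shown stands there too (the limit of > 125000 nM in this assay, at which 2 of the 2 values shown sit).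

Compound 3 `COc1cc2cc(C#N)ccc2c(OC)c1Oc1cc(NCC(O)CO)nc(Nc2ccc(C#N)cc2)n1` has not been measured. It differs from compound 2 by 2,3-dihydroxypropyl in place of cyclopropyl on a nitrogen on an aromatic ring. For the measured compounds named here, no measured step bears on this change, and the one step known gives no size at all. Compound 3 is thus expected to remain at the limit as well, so that a step that the limit leaves unreadable from compound 2 to compound 3 is expected to be no step beyond the scatter. The estimate for compound 3 in this assay is 150000 nM, within a range from 100000 nM to 300000 nM.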

Compound 3, half-maximal cytotoxic concentration: 29500 nM
For compound 3 the middle estimate is 5.1-fold (0.71 log units) above the measured one; measured number below the stated range.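

The nitrogen on an aromatic ring is not a silent position in this assay: 2,3-dihydroxypropyl in place of cyclopropyl gives an at least 4.2-fold lower number from compound 2 to compound 3 (0.62 log units; beyond the scatter), and the comparison with the isobutyl amine gives an at least 4.2-fold lower number from compound 1 to compound 3 (0.62 log units; beyond the scatter). Among the compounds shown here, the step between the two earlier compounds cannot be read, so this is the first sign that the group on this nitrogen can change how much compound is tolerated. Only compound 3 has a value that is a number, while the other two values are limits of the assay: the limit of > 125000 nM in this assay, at which 2 of the 3 values shown sit.

The compounds shown do not separate the two hydroxyl groups from the rest of the change, since the cyclopropyl ring leaves as they enter. A 2-hydroxyethylamino or 2,3-dimethoxypropylamino group on this nitrogen would bear on that question.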